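The compounds below may be only part of what the source reports. "The series", "measured", "known", "first", "only" and "open" are said of these compounds alone.

Measured so far in an ADME assay on L132 cells (Homo sapiens) for cytotoxicity, read by MTT assay, with a stated time of 48 h; a higher number here means a weaker inhibitor, a lower number a stronger inhibitor:
Compound 1 `COc1ccccc1-n1cc(COC(=O)/C(C)=C/CC/C(C)=C/CC/C(C)=C/CC[C@@H]2[C@@]3(C)CCC(=O)C(C)(C)[C@H]3CC[C@@]2(C)O)nn1`: > 150000 nM, a limit.
Compound 2 `C/C(=C\CC/C(C)=C/CC[C@@H]1[C@@]2(C)CCC(=O)C(C)(C)[C@H]2CC[C@@]1(C)O)CC/C=C(\C)C(=O)OCc1cn(-c2ccccc2)nn1`: > 150000 nM, a limit.
Compound 3 `C/C(=C\CC/C(C)=C/CC[C@@H]1[C@@]2(C)CCC(=O)C(C)(C)[C@H]2CC[C@@]1(C)O)CC/C=C(\C)C(=O)OCc1cn(-c2ccccc2F)nn1`: > 150000 nM, a limit.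

Compound 3 has no number and stands with the other two at one limit: the limit of > 150000 nM in this assay, at which 3 of the 3 values shown sit. Compound 4 `C/C(=C\CC/C(C)=C/CC[C@@H]1[C@@]2(C)CCC(=O)C(C)(C)[C@H]2CC[C@@]1(C)O)CC/C=C(\C)C(=O)OCc1cn(-c2ccc(C(C)(C)C)cc2)nn1` is still unmeasured and differs from compound 3 as follows: 4-(tert-butyl)phenyl in place of 2-fluorophenyl on an aromatic nitrogen. Among the compounds with values here, three measured steps bear on this change, all on the same aromatic ring: a step that the two limits leave unreadable from compound 1 to compound 2, a step that the two limits leave unreadable from compound 1 to compound 3 and a step that the two limits leave unreadable from compound 2 to compound 3. None of them gives a size, so no step beyond the scatter is expected in this assay. The estimated step is a step that the limit leaves unreadable from compound 3 to compound 4. For compound 4 the expected value is 160000 nM, with an estimated range of 70000 nM to 300000 nM.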

Compound 4, half-maximal inhibitory concentration: 65800 nM
Estimate against measurement, compound 4: 2.4-fold (0.39 log units) above; the measured number lies below the stated range.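

The aromatic ring on the triazole nitrogen can shift the read-out in this assay and the new steps give the first sizes for this position. The exchange of 2-fluorophenyl for 4-(tert-butyl)phenyl gives an at least 2.2-fold lower number from compound 3 to compound 4 (0.35 log units; beyond the scatter) and tert-butyl in place of hydrogen gives an at least 2.2-fold lower number from compound 2 to compound 4 (0.35 log units; beyond the scatter) while the exchange of 2-methoxyphenyl gives an at least 2.2-fold lower number from compound 1 to compound 4 (0.35 log units; beyond the scatter). The steps among compound 1, compound 2 and compound 3 cannot be read, and compound 4 alone has a number rather than a limit: the limit of > 150000 nM in this assay, at which 3 of the 4 values shown sit.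

Going by these compounds, whether a smaller alkyl group such as methyl, or an amine or a carboxylic acid in place of tert-butyl, would also lower the number stays open. On these data alone, the true size of each step also stays open.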